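This account rests on a few compounds, and the source may have more. Where it says the series, first, only, none or still open, it means among the compounds named here.

Measured so far:
- compound 1 `NC1=NC2(CCSCC2)N(OCCCOc2ccc(Cl)c(Cl)c2)C(N)=N1`, which in an assay on isolated protein for inhibition of Dihydrofolate reductase (Homo sapiens), read by spectrophotometry, using NADPH, with stated times of 5 s and 6 min, tested at 5 uM (a higher number here means a stronger effect of the compound at the concentration tested, a lower number a weaker effect), gives 88.4%.
- compound 2 `NC1=NC2(CCOCC2)N(OCCCOc2ccc(Cl)cc2)C(N)=N1`, which in this assay gives > 90%, a limit of the assay and not a number.

Compound 2 stands at the limit of this assay (the limit of > 90% in this assay, at which 1 of the 2 values shown sits), so only a range is known for it. Compound 1 also stands high in this assay; both values sit at the strong end of the scale.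

Compound 3 `Cc1cc(C)cc(OCCCON2C(N)=NC(N)=NC23CCOCC3)c1` is yet to be measured. It differs from compound 2 by 3,5-dimethylphenyl in place of 4-chlorophenyl on an oxygen on a saturated carbon. Going by the values given here, no step between measured compounds covers this change, so there is nothing measured to lean on. The expected step is a number at least 6 percentage points lower from compound 2 to compound 3 (that floor lies within the scatter), small and downward, within or only just beyond the scatter. Compound 3 is expected to give 84% in this assay, with a range from 62% to 95%.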

Compound 3, a percentage reported as inhibition, at one concentration (the size of the read-out at that concentration, not a potency): 84.3%
The estimate for compound 3 lay 0.3 percentage points below the measured number, and the stated range covers the measured number.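

In this assay, the step for 3,5-dimethylphenyl in place of 4-chlorophenyl on the oxygen on a saturated carbon is a number at least 5.7 percentage points lower from compound 2 to compound 3 (that floor lies within the scatter). The read-out of compound 3, 84.3%, stays high at the concentration tested, so a chlorine on this ring is not needed for a high read-out in this pair. The full size of the step cannot be read, because compound 2 stands at a limit of the assay and not at a number: the limit of > 90% in this assay, at which 1 of the 3 values shown sits.

The compounds shown leave open whether an amine or a carboxylic acid on this ring would keep the read-out high, and what a longer chain to the oxygen would do. As far as these compounds go, with single-concentration percentages near the top of the scale, any difference in potency also stays open.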